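The compounds below may be only part of what the source reports. "The series", "measured", "known", "first", "only" and "open" are said of these compounds alone.

Compound 1 `CC(=O)c1nn(-c2ccc(Cl)cc2)/c(=N/c2nc(-c3c(C)n(C)n(-c4ccccc4)c3=O)cs2)s1` gives > 100000 nM in a functional assay on HepG2 cells (Homo sapiens) for cytotoxicity, read by sulforhodamine B assay, with a stated time of 72 h (a lower number here means a stronger inhibitor, a higher number a weaker inhibitor), which is a limit of the assay rather than a number.
Compound 2 `CCOC(=O)c1nn(-c2ccccc2)/c(=N/c2nc(-c3c(C)n(C)n(-c4ccccc4)c3=O)cs2)s1` gives > 100000 nM in this assay, again a limit.
Compound 3 `CCOC(=O)c1nn(-c2ccc(Cl)cc2)/c(=N/c2nc(-c3c(C)n(C)n(-c4ccccc4)c3=O)cs2)s1` gives > 100000 nM in this assay, also a limit.

Compound 3 therefore stands at the limit, as do the other two measured compounds: the limit of > 100000 nM in this assay, at which 3 of the 3 values shown sit. The step to compound 4 `CCOC(=O)c1nn(-c2ccc(OC)cc2)/c(=N/c2nc(-c3c(C)n(C)n(-c4ccccc4)c3=O)cs2)s1` is methoxy in place of chloro on an aromatic carbon. For the measured compounds named here, two measured steps touch the same region of the shared core, but neither can be read, because a step that the two limits leave unreadable from compound 1 to compound 3 and a step that the two limits leave unreadable from compound 2 to compound 3 both run between limits. Going by the values given here, no measured step shows whether changing the group on this ring moves the read-out at all, so no size or direction of step is expected beyond the scatter; the expected step in this assay is a step that the limit leaves unreadable from compound 3 to compound 4. Compound 4 is therefore expected to sit at the limit again, with an estimate of 150000 nM and a range from 50000 nM to 500000 nM.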

Compound 4, half-maximal inhibitory concentration: 12900 nM
The estimate for compound 4 lay 12-fold (1.07 log units) above the measured number; the measured number lies below the stated range.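

For the compounds shown here, the change from 4-chlorophenyl to 4-methoxyphenyl gives an at least 7.7-fold lower number from compound 3 to compound 4 (0.88 log units; beyond the scatter) in this assay, which shows for the first time that the group on this aromatic carbon, para to a large group, can move the read-out. The same place with hydrogen gives an at least 7.7-fold lower number from compound 2 to compound 4 (0.88 log units; beyond the scatter), so in this series the lower number goes with methoxy and not merely with the loss of chloro. The earlier steps among compound 1, compound 2 and compound 3 still cannot be read, and the only readable steps are those that end at compound 4, since the other three values are limits: the limit of > 100000 nM in this assay, at which 3 of the 4 values shown sit.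

As far as these compounds go, both readable steps start from a limit, so their true size remains unknown. From the compounds shown here alone, it also remains open whether a hydroxyl, an amine or a longer chain at this place would lower the number further.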